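Swapping an Aryl Ether for a Cyclopentyl Ether

A few compounds are considered here, and "the series" means these few. Any claim that something is new, unique, unknown or untested is made for them only; others in the source may bear on it.

Of the compounds shown here, three have so far been tested in an assay on HEK293 cells for inhibition of N-acylethanolamine-hydrolyzing acid amidase (Rattus norvegicus), read by LC-MS, with a stated time of 30 min; on this read-out higher numbers stand for weaker inhibition and lower numbers for stronger inhibition. Compound 1 `O=C(CCCCCc1cccc(I)c1)N1CCOC1=O` gives 3120 nM. Compound 2 `NC(=O)c1ccc(CCCCCC(=O)N2CCOC2=O)cc1` reaches only (the limit of > 20000 nM in this assay, at which 1 of the 3 values shown sits), reported as > 20000 nM, which is a limit of the assay and not a number. Compound 3 `Cc1cccc(Oc2ccc(C(=O)N3CCOC3=O)cc2)c1` gives 5210 nM, a value that sits alongside that of compound 1, the two within the usual scatter of each other. Compound 4 `O=C1OCCN1C(=O)c1ccc(OC2CCCC2)cc1` has not yet been measured in this assay; it differs from compound 3 by cyclopentyl in place of 3-methylphenyl on an oxygen on an aromatic ring. Among the measured compounds shown here, no measured pair shows a change of this kind, so its size is open, and the expected step, a 1.5-fold lower number from compound 3 to compound 4 (0.17 log units; within the scatter), is small with no clear direction beyond the scatter. Compound 4 is estimated at 3500 nM, within 900 nM to 14000 nM.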

Compound 4, half-maximal inhibitory concentration: 120 nM
Compound 4: the middle estimate sits 29-fold (1.46 log units) above what was measured, and the stated range ends above it.
By their numbers in this assay, from the lowest: compound 4; then compounds 1 and 3 (each within the scatter of the next). At a limit, above all of these: compound 2.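

In this assay, the group on this oxygen proves to matter a great deal: cyclopentyl in place of 3-methylphenyl gives a 43-fold lower number from compound 3 to compound 4 (1.64 log units; beyond the scatter). This is the first pair shown that differs in one place, and it reveals that this position responds strongly to change. Among the compounds shown here, nothing measured so far accounts for the size of this step. For the compounds shown here, the single change alters both ring size and aromatic character, so the contribution of each remains unresolved. Also open, as far as these compounds go, is how cyclobutyl, cyclohexyl or an open-chain butyl group would fare on this oxygen.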